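The source may hold more compounds than are shown below. What is called first, only, known or untested is meant among the compounds shown, and "the series" means these compounds.

Compound 1 `Cc1ccc(NC(=O)[C@H](CCCCCC(=O)NO)NC(=O)[C@H]2CCC(=O)N2)cc1`: 156 nM in an assay on isolated protein for inhibition of histone deacetylase 8 (Homo sapiens), read by fluorescence; a lower number here means a stronger inhibitor, a higher number a weaker inhibitor.
Compound 2 `O=C(CCCCCCC(=O)Nc1cccc(C(F)(F)F)c1)NO`: 113 nM in this assay.

Compound 1 gives the highest of the two numbers, with compound 2 a short distance lower and within the scatter, so no order between them is claimed. Compound 3 `Cc1ccc(NC(=O)CCCCCCC(=O)NO)cc1` differs from compound 1 by hydrogen in place of ((5-oxopyrrolidin-2-yl)carbonyl)amino on a saturated chain carbon bound to a carbonyl carbon and a saturated chain carbon, leaving a plain chain anilide. Among the compounds with values here, no measured pair isolates this change. Compound 2, with 113 nM, carries no such group and is the closest guide. The step of a 1.0-fold lower number from compound 1 to compound 3 (0.02 log units; within the scatter) is therefore expected to stay within the scatter, in no set direction. Compound 3 is estimated at 150 nM, range 50 nM to 500 nM.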

Compound 3, half-maximal inhibitory concentration: 336 nM
Compound 3: the middle estimate sits 2.2-fold (0.35 log units) below what was measured; the measured number falls inside the stated range.
By their numbers in this assay, from the lowest: compounds 2 and 1 (each within the scatter of the next); then compound 3.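

In this assay, the step of a 2.2-fold higher number from compound 1 to compound 3 (0.33 log units; beyond the scatter) shows that this saturated chain carbon is not indifferent to substitution: with hydrogen in place of ((5-oxopyrrolidin-2-yl)carbonyl)amino, the number rises modestly. This reading rests on one pair. No evidence on the cause of the step is available.

Still open, as far as these compounds go, is whether the ring is needed at this carbon, or whether a simple acetylamino group or a free amine would give the same number. From the compounds shown here alone, the effect of the opposite configuration at this carbon also remains open.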